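Swapping a carbamate for an oxadiazole on the ring nitrogen

This account rests on a few compounds, and the source may have more. Where it says the series, first, only, none or still open, it means among the compounds named here.

Three compounds have been measured in a functional assay on CHO-K1 cells for agonist activity at Glucose-dependent insulinotropic receptor (Homo sapiens), read by a luciferase reporter, with a stated time of 5 h; on this read-out higher numbers stand for an effect only at larger amounts of compound and lower numbers for an effect already at smaller amounts:

Compound 1 `CC(C)OC(=O)N1CCC(Oc2ncnc3c2CCN3c2ccc(S(C)(=O)=O)cc2)CC1` gives 126 nM.
Compound 2 `CC(C)OC(=O)N1CCC(Oc2ncnc3c2CCN3c2ccc(-c3nccs3)cc2F)CC1` gives 79.4 nM.
Compound 3 `CS(=O)(=O)c1ccc(N2CCc3c(OC4CCN(C(=O)OCCF)CC4)ncnc32)c(F)c1` gives 501 nM.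

Among these three numbers compound 3 stands highest, and the gap to compound 1, its nearest neighbour, as well as the gap to compound 2, its furthest, both lie beyond the usual scatter. Compound 3 is therefore the one of the three that needs the largest amount of compound for a half-maximal effect.

Compound 4 `CC(C)c1noc(N2CCC(Oc3ncnc4c3CCN4c3ccc(S(C)(=O)=O)cc3F)CC2)n1` is not yet measured. It differs from compound 3 in a single place: 3-isopropyl-1,2,4-oxadiazol-5-yl in place of (2-fluoroethoxy)carbonyl on an amine nitrogen in a ring. The amine nitrogen in a ring thus carries a five-membered aromatic ring with three hetero atoms instead of an open chain bearing a carbonyl and a fluorine.

Going by the values given here, no pair of measured compounds differs in exactly this way, so there is no measured step to lean on. The expectation is that compound 4 moves to a somewhat lower number than compound 3, with a 2.5-fold lower number from compound 3 to compound 4 (0.40 log units; beyond the scatter) as the expected step in this assay, though a result within the scatter cannot be excluded. Compound 4 is estimated to give 200 nM, with a range from 60 nM to 700 nM.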

Compound 4, half-maximal effective concentration: 79.4 nM
Estimate against measurement, compound 4: 2.5-fold (0.40 log units) above; low and high end bracket the measured number.
By their numbers in this assay, from the lowest: compounds 2, 4 and 1 (each within the scatter of the next); then compound 3.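

In this assay, placing 3-isopropyl-1,2,4-oxadiazol-5-yl on the amine nitrogen in a ring in place of (2-fluoroethoxy)carbonyl gives a 6.3-fold lower number from compound 3 to compound 4 (0.80 log units; beyond the scatter), a change beyond the usual scatter. Going by these compounds alone, this is the first measured step at this position, and it shows that the nitrogen need not carry a carbonyl for the compound to act on this receptor: with the five-membered aromatic ring, less compound is needed for a half-maximal effect. The incoming group is also the larger one by heavy-atom count, so in this pair a bigger group at this nitrogen goes with a lower number, but the data shown give no measurement that explains the step.

The step swaps a whole group, so it cannot say how much comes from the aromatic ring and how much from the isopropyl on it, or from the loss of the fluorine. A methyl or a cyclopropyl in place of that isopropyl, or a pyrimidine ring in place of the oxadiazole, would help separate these parts, and a single pair cannot say whether the same swap would hold with another group on the rest of the molecule.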